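Swapping tert-butyl for a chlorophenylsulfonamide on the triazole

The source may report more compounds than this note shows. Statements on the series, on what has been measured and on what is new or still open speak of the compounds shown alone.

Compound 1 `O=C1O[C@H]([C@@H](O)Cn2cc(CNS(=O)(=O)c3ccc(F)cc3)nn2)C(OCc2ccccc2)=C1OCc1ccccc1` and compound 2 `CC(C)(C)c1cn(C[C@H](O)[C@H]2OC(=O)C(OCc3ccccc3)=C2OCc2ccccc2)nn1` share one core and differ only at one aromatic carbon. In a functional assay on A549 cells (Homo sapiens) for antiproliferative activity, read by MTT assay, with a stated time of 72 h (a lower number here means a stronger inhibitor, a higher number a weaker inhibitor), compound 1 gives 22500 nM and compound 2 gives 34000 nM; the step of a 1.5-fold higher number from compound 1 to compound 2 (0.18 log units; within the scatter) stays within the scatter, so compound 2 simply stands among these two. Compound 3 `O=C1O[C@H]([C@@H](O)Cn2cc(CNS(=O)(=O)c3ccc(Cl)cc3)nn2)C(OCc2ccccc2)=C1OCc1ccccc1` brings ((((4-chlorophenyl)sulfonyl)amino)methyl in place of tert-butyl on an aromatic carbon). Going by the values given here, the one measured step that bears on this is the reverse exchange with a fluorine instead of chlorine, a 1.5-fold higher number from compound 1 to compound 2 (0.18 log units; within the scatter), which showed no step beyond the scatter, so none is expected here in this assay. Compound 3 is therefore estimated at 22000 nM, between 10000 nM and 45000 nM, a step of a 1.5-fold lower number from compound 2 to compound 3 (0.19 log units; within the scatter).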

Compound 3, half-maximal inhibitory concentration: 2870 nM
Compound 3: middle estimate off by 7.7-fold (0.88 log units), on the high side; measured number outside the range, below it.
By their numbers in this assay, from the lowest: compound 3; then compounds 1 and 2 (each within the scatter of the next).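

In this assay, exchanging one halogen on the sulfonamide's aromatic ring gives a 7.8-fold lower number from compound 1 to compound 3 (0.89 log units; beyond the scatter) even though the fluoro compound 1 stood within the scatter of the tert-butyl compound 2. The full exchange gives a 12-fold lower number from compound 2 to compound 3 (1.07 log units; beyond the scatter) and shows that a change at this triazole carbon can move the number beyond the scatter, but among these three compounds only the version carrying chloro does so. Nothing here explains why this single-atom exchange matters. From the compounds shown here alone, it remains open whether bromo or methyl in place of the chloro would keep, extend or lose this gain.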